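This account rests on a few compounds, and the source may have more. Where it says the series, first, only, none or still open, it means among the compounds named here.

Measured in a functional assay on MES-SA cells (Homo sapiens) for inhibition, with a stated time of 72 h; on this read-out higher numbers stand for weaker inhibition and lower numbers for stronger inhibition:
- Compound 1 `Oc1c(CN2CCCCC2)ccc2cccnc12`: 5210 nM; 5130 nM (2 entries)
- Compound 2 `COCc1cc(CN2CCCCC2)c(O)c2ncccc12`: 9330 nM
- Compound 3 `CCOCc1cc(CN2CCCCC2)c(O)c2ncccc12`: 8710 nM

Repeat measurements of compound 1 agree closely: the several entries of compound 1 in this assay, 5210 nM; 5130 nM (2 entries). In this assay, compound 3 stands at 8710 nM. Within the data shown here, the one measured step leading to it, a 1.1-fold lower number from compound 2 to compound 3 (0.03 log units; within the scatter), replaces hydrogen with methyl on a saturated chain carbon bound to an oxygen, and it stays within the scatter.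

Compound 4 `CCCOCc1cc(CN2CCCCC2)c(O)c2ncccc12` lengthens the chain once more, from ethoxy to propoxy: methyl in place of hydrogen on a saturated chain carbon, two bonds along the chain from an oxygen on a saturated carbon. That earlier step is the closest guide, so no shift beyond the scatter is expected. The expected change is a 1.0-fold lower number from compound 3 to compound 4 (0.01 log units; within the scatter). Compound 4 is estimated at 8500 nM, with an expected range from 5000 nM to 14000 nM.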

Compound 4, half-maximal inhibitory concentration: 3720 nM
The estimate for compound 4 lay 2.3-fold (0.36 log units) above the measured number, outside the stated range (below it).
By their numbers in this assay, from the lowest: compound 4; then compounds 3 and 2 (each within the scatter of the next).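

Going from ethoxy to propoxy gives a 2.3-fold lower number from compound 3 to compound 4 (0.37 log units; beyond the scatter) and moves the number beyond the scatter, which the earlier step from methoxy to ethoxy did not do. Counted from methoxy, the change to propoxy gives a 2.5-fold lower number from compound 2 to compound 4 (0.40 log units; beyond the scatter) and is likewise modest, so at this position chain length can alter the read-out. Repeat readings in this assay sit close together, which makes steps of this size easier to trust: the several entries of compound 1 in this assay, 5210 nM; 5130 nM (2 entries)

On these data alone, whether a butoxy group or a longer chain would lower the number further remains open. So does whether an amine or a carboxylic acid on this chain would keep the lower number.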